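Removing the ring hydroxy from compound 3

The source may report more compounds than this note shows. Statements on the series, on what has been measured and on what is new or still open speak of the compounds shown alone.

In a functional assay on HepG2 cells (Homo sapiens) for cytotoxicity, read by colorimetric assay and neutral red uptake, with a stated time of 72 h (a lower number here means a stronger inhibitor, a higher number a weaker inhibitor), compound 1 (`CO[C@@H](C(=O)N[C@H]1CCCCNC1=O)[C@H](O)[C@@H](O)[C@H](O)/C=C/C(C)(C)C`) gives 21100 nM. Compound 2 (`CO[C@@H](C(=O)N[C@H]1CCCCNC1=O)[C@@H]1OC(C)(C)O[C@H](/C=C/C(C)(C)C)[C@@H]1O`) reads > 150000 nM, which is a limit. Compound 3 (`CO[C@@H](C(=O)N[C@H]1CC[C@@H](O)CNC1=O)[C@H](O)[C@@H](O)[C@H](O)/C=C/C(C)(C)C`) reads > 150000 nM, also a limit, so its position is bounded and not fixed by a number.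

Compound 4 (`CO[C@@H](C(=O)N[C@@H]1CCCCNC1=O)[C@H](O)[C@@H](O)[C@H](O)/C=C/C(C)(C)C`) carries 2-oxoazepan-3-yl in place of 6-hydroxy-2-oxoazepan-3-yl on an amide-type nitrogen. Within the data shown here, the one measured step bearing on this is an at least 7.1-fold higher number from compound 1 to compound 3 (0.85 log units; beyond the scatter), where the hydroxy comes in, and it is bounded by a limit. Losing the hydroxy therefore points to a lower number in this assay, but a single step keeps this expectation loose.

The expected change is an at least 2.1-fold lower number from compound 3 to compound 4 (0.33 log units; beyond the scatter).

For compound 4, the estimated value is 70000 nM, with an expected range of 20000 nM to 150000 nM.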

Compound 4, half-maximal inhibitory concentration: 1100 nM
Beside the measured number, compound 4's estimate is 64-fold (1.80 log units) above it; measured number below the stated range.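

In this assay, the change on the amide-type nitrogen gives an at least 130-fold lower number from compound 3 to compound 4 (2.13 log units; beyond the scatter). The ring stereocentre matters on its own, with a 19-fold lower number from compound 1 to compound 4 (1.28 log units; beyond the scatter), and this difference can only be assigned to configuration because no other feature separates the pair: the fact that compounds 1 and 4 differ only in the configuration as drawn. The large step to compound 4 therefore cannot be credited to losing the hydroxy alone.

As far as these compounds go, what the hydroxy does with the ring configuration of compound 4 remains open. So does the effect of an amine in place of that hydroxy.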